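A Bromine Added Where No Measured Step Has Gone

The source may report more compounds than this note shows. Statements on the series, on what has been measured and on what is new or still open speak of the compounds shown alone.

Three compounds share one core and differ only in the aryl group carried on the chain carbon. In a functional assay on HeLa cells (Homo sapiens) for cytotoxicity, read by MTT assay, with a stated time of 48 h (on this read-out higher numbers stand for weaker inhibition and lower numbers for stronger inhibition), compound 1 `O=C1C(O)=C(C(c2ccc(F)cc2)c2c[nH]c3ccccc23)C(=O)c2ccccc21` gives 15800 nM. Compound 2 `O=C1C(O)=C(C(c2ccc([N+](=O)[O-])cc2)c2c[nH]c3ccccc23)C(=O)c2ccccc21` gives 14800 nM in this assay, and compound 3 `COc1cccc(C(C2=C(O)C(=O)c3ccccc3C2=O)c2c[nH]c3ccccc23)c1` gives 25600 nM. Compound 2 stands together with the other two: the steps of a 1.1-fold lower number from compound 1 to compound 2 (0.03 log units; within the scatter), a 1.6-fold higher number from compound 1 to compound 3 (0.21 log units; within the scatter) and a 1.7-fold higher number from compound 2 to compound 3 (0.24 log units; within the scatter) all lie within the scatter, so the three numbers cannot be told apart.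

Compound 4 `O=C1C(O)=C(C(c2ccc([N+](=O)[O-])cc2)c2c[nH]c3ccc(Br)cc23)C(=O)c2ccccc21` arises from compound 2 by bromo in place of hydrogen on an aromatic carbon. Within the data shown here, none of the measured steps touches this position; each of them alters the aryl group on the chain carbon, and each stayed within the scatter. Among the measured compounds shown here, no measured step bears on the new change, so the expectation rests only on the flat picture seen so far. In this assay the step of no change at the digits printed from compound 2 to compound 4 (within the scatter) is expected, that is, none beyond the scatter. Compound 4 is therefore estimated at 14800 nM, with a range from 6000 nM to 37000 nM.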

Compound 4, half-maximal inhibitory concentration: 14100 nM
The estimate for compound 4 lay 1.0-fold (0.02 log units) above the measured number; the measured number falls inside the stated range.
By their numbers in this assay, from the lowest: compounds 4, 2, 1 and 3 (each within the scatter of the next).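

The earlier compounds shown here varied only the aryl group on the chain carbon, so this change gives the first reading from a different part of the molecule, where 1H-indol-3-yl becomes 5-bromo-1H-indol-3-yl. In this assay the step is a 1.0-fold lower number from compound 2 to compound 4 (0.02 log units; within the scatter) and shows that, with the 4-nitrophenyl group in place, one bromine at this position leaves the number indistinguishable from that of the parent compound. The data at hand offer no explanation for this result.

As far as these compounds go, it remains open whether the same position would stay equally flat with an amine or a carboxylic acid there in place of the bromine. Also open, from the compounds shown here alone, is whether bromo gives the same reading when the chain carbon carries the 4-fluorophenyl or 3-methoxyphenyl group instead.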